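Compound 3: Cyclopentyl in Place of Isobutyl

The source may report more compounds than this note shows. Statements on the series, on what has been measured and on what is new or still open speak of the compounds shown alone.

Of the compounds shown here, two have so far been measured in a functional assay on HCT-116 cells (Homo sapiens) for cytotoxicity, read by MTT assay, with a stated time of 72 h; a higher number here means a weaker inhibitor, a lower number a stronger inhibitor. Compound 1 `O=C(c1cccc2ccccc12)n1c(C2CCC2)nc2ccccc21` returned only a limit, > 10000 nM. For the measured compounds named here, compound 2 `COc1ccc(C(=O)n2c(CC(C)C)nc3ccccc32)cc1` gave 3560 nM, the only actual number available, so it has no measured value to be ranked against. Compound 3 `COc1ccc(C(=O)n2c(C3CCCC3)nc3ccccc32)cc1` keeps the rest of compound 2 and differs in one place: cyclopentyl in place of isobutyl on an aromatic carbon, with cyclopentyl in place of isobutyl on an aromatic carbon, between two ring nitrogen atoms. Going by the values given here, no measured step shows what such a change does, so the expectation rests on compound 2 alone, at 3560 nM. No shift beyond the usual scatter is expected in this assay, and the estimated step is a 1.1-fold higher number from compound 2 to compound 3 (0.05 log units; within the scatter). For compound 3 the expected value is 4000 nM, with an estimated range from 1400 nM to 12000 nM.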

Compound 3, half-maximal inhibitory concentration: > 10000 nM
Compound 3: only a limit was reported; the forecaster's own chance of this, stated with the estimate: 15%; middle value at least 2.5-fold (0.39 log units) away from the limit.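

In this assay, the position on an aromatic carbon between two ring nitrogen atoms proves sensitive to the group it carries: cyclopentyl in place of isobutyl, with no hydrogen-bond donors or acceptors on either group, gives an at least 2.8-fold higher number from compound 2 to compound 3 (0.44 log units; beyond the scatter). The value of compound 3, > 10000 nM, is a limit and not a number. The true size of the step stays unknown because of a limit that the values share: the limit of > 10000 nM in this assay, at which 2 of the 3 values shown sit.

The compounds shown leave open whether the ring of cyclopentyl or its larger number of carbon atoms accounts for the step, since compound 2 alone carries a number. As far as these compounds go, how an ethyl group, a longer chain such as n-pentyl or a cyclopropyl ring would read at this position also remains open.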